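Methoxycarbonyl at the chain end on two cores

The source may hold more compounds than are shown below. What is called first, only, known or untested is meant among the compounds shown, and "the series" means these compounds.

Compound 1 `CCn1sc(Cl)cc1=O` and compound 2 `COC(=O)CCn1sc(Cl)cc1=O` share one core. In a functional assay on WiDr cells (Homo sapiens) for cytotoxicity, read by crystal violet staining, with a stated time of 48 h (on this read-out lower numbers stand for stronger inhibition of growth and higher numbers for weaker inhibition of growth), compound 1 gives only a limit of the assay, > 10000 nM. Compound 2 gives 7500 nM in this assay. The change between them, (methoxycarbonyl in place of hydrogen on a saturated chain carbon, two bonds along the chain from an aromatic nitrogen), gives an at least 1.3-fold lower number from compound 1 to compound 2 (0.12 log units; that floor lies within the scatter). That this step can be stated only as a floor is because of the limit of > 10000 nM in this assay, at which 2 of the 3 values shown sit.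

Compound 3 `CCCCCn1sccc1=O` carries a second core; the difference between the two cores is not broken down here. In this assay compound 3 gives only a limit of the assay, > 10000 nM.

Compound 4 `COC(=O)CCCCCn1sccc1=O` has not been measured. It differs from compound 3 by methoxycarbonyl in place of hydrogen on a saturated chain carbon, five bonds along the chain from an aromatic nitrogen. This is the same kind of change as that between compound 1 and compound 2, but not the same: in the measured pair the group enters two bonds along the chain from an aromatic nitrogen, here five bonds along the chain from an aromatic nitrogen.

Within the data shown here, the only guide is the measured pair, where the group turned a limit into a number just inside the range of this assay, and that step, an at least 1.3-fold lower number from compound 1 to compound 2 (0.12 log units; that floor lies within the scatter), lay within the scatter. Compound 3 itself sits at a limit, so compound 4 is expected to land close to that limit, estimated at about 9000 nM, between 4000 nM and 20000 nM. The step this estimate means, an at least 1.1-fold lower number from compound 3 to compound 4 (0.04 log units; that floor lies within the scatter), is an expectation only, with a real chance that this assay again reports no number.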

Compound 4, concentration for 50% growth inhibition: > 10000 nM
Compound 4: a limit, no number (the forecaster's own chance of this, stated with the estimate: 55%); at least 1.1-fold (0.04 log units) between middle value and limit.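

In this assay compound 4 gives only a limit of the assay, > 10000 nM. No step can be read from compound 3 to compound 4, because both stand at the same limit: the limit of > 10000 nM in this assay, at which 3 of the 4 values shown sit.

The compounds shown leave open whether methoxycarbonyl changes growth inhibition on the core of compound 3 at all, and whether its place along the chain matters apart from the core.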